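A Dichlorophenoxy-to-Sulfanyl Series of Diaminoquinoxalines Under Test

The source may report more compounds than this note shows. Statements on the series, on what has been measured and on what is new or still open speak of the compounds shown alone.

The study measures cell killing in a functional assay on MCF7 cells (Homo sapiens) for inhibition, read by sulforhodamine B assay, with a stated time of 48 h; on this read-out lower numbers stand for higher toxicity in this test and higher numbers for lower toxicity in this test. Compound 1 `Nc1cc(N)c2nc(-c3ccccc3)c(Oc3ccc(Cl)c(Cl)c3)nc2c1` carries a 3,4-dichlorophenoxy group on the shared core. In this assay compound 1 gives < 100000 nM, which is a limit of the assay and not a number. Compound 2 `Nc1cc(N)c2nc(-c3ccccc3)c(NCc3ccc(F)cc3)nc2c1` carries a (4-fluorobenzyl)amino group in the same position. In this assay compound 2 gives < 100000 nM, again a limit of the assay rather than a number. The step that the two limits leave unreadable from compound 1 to compound 2 therefore cannot be read. Both values shown sit at the same limit, as the limit of < 100000 nM in this assay, at which 2 of the 2 values shown sit, records, so compound 2 stands only at a limit, with no number to place it.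

Compound 3 `COc1ccc(Sc2nc3cc(N)cc(N)c3nc2-c2ccccc2)cc1` differs from compound 2 by (4-methoxyphenyl)sulfanyl in place of (4-fluorobenzyl)amino on an aromatic carbon. Within the data shown here, no measured step gives a readable size, so the only evidence that bears on compound 3 is that both neighbours fall under the limit. The estimated step that the limit leaves unreadable from compound 2 to compound 3 is therefore expected to lie within the scatter, and compound 3 is expected to give about 30000 nM in this assay, within the range 5000 nM to 100000 nM, most likely reported again only as a limit.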

Compound 3, concentration lethal to 50% of the cells: < 100000 nM
Compound 3: only a limit was reported; the forecaster's own chance of this, stated with the estimate: 70%; the middle value is on the limit's open side.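

In this assay compound 3 gives < 100000 nM, a limit of the assay and not a number. Among these compounds, no step from compound 1 or compound 2 to compound 3 can be read, because all three sit at one limit: the limit of < 100000 nM in this assay, at which 3 of the 3 values shown sit. The compounds shown leave open whether the 3,4-dichlorophenoxy, (4-fluorobenzyl)amino and (4-methoxyphenyl)sulfanyl groups differ at all in this read-out.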